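The compounds below may be only part of what the source reports. "The series", "measured", "known", "first", "only" and "open" are said of these compounds alone.

Measured so far:
- compound 1, `O=S(=O)(Nc1ccc(Cl)c(Cl)c1)c1ccc(-c2cnc(C3CC3)o2)cc1`: > 100000 nM
- compound 2, `O=S(=O)(Nc1ccc(F)cc1F)c1ccc(-c2cnc(C3CC3)o2)cc1`: > 100000 nM

In a functional assay on cells (leukaemia cell line, Homo sapiens) for inhibition, read by sulforhodamine B assay, with a stated time of 48 h (a lower number here means that less compound is tolerated, a higher number that more compound is tolerated), compound 1 reaches only the limit of the assay, > 100000 nM, not a number. Compound 2 likewise reaches only the limit, > 100000 nM. Going by the values given here, the one measured step, a step that the two limits leave unreadable from compound 1 to compound 2, is therefore not readable; both values sit at the limit of > 100000 nM in this assay, at which 2 of the 2 values shown sit. Compound 2 thus stands at the limit, with no number to place it.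

Compound 3, `Cc1cc(Cl)cc(NS(=O)(=O)c2ccc(-c3cnc(C4CC4)o3)cc2)c1`, is not yet measured. Relative to compound 2 the change is 3-chloro-5-methylphenyl in place of 2,4-difluorophenyl on a sulfonamide nitrogen. Among the compounds with values here, no measured step shows a variation on the sulfonamide nitrogen moving a value off the limit, so no shift in this assay beyond the scatter is expected: the step from compound 2 to compound 3 is estimated as a step that the limit leaves unreadable from compound 2 to compound 3. For compound 3 the expected value is 150000 nM, within a range of 60000 nM to 400000 nM, most probably reported again only as a limit.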

Compound 3, concentration lethal to 50% of the cells: 84900 nM
Compound 3: the middle estimate sits 1.8-fold (0.25 log units) above what was measured; low and high end bracket the measured number.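

In this assay, this position on the sulfonamide nitrogen now yields a number: with 3-chloro-5-methylphenyl in that place, compound 3 gives 84900 nM. Going by these compounds, the change reads as an at least 1.1-fold lower number from compound 2 to compound 3 (0.07 log units; that floor lies within the scatter), and the same holds for an at least 1.1-fold lower number from compound 1 to compound 3 (0.07 log units; that floor lies within the scatter); each is only a floor, so the true size of either step remains unknown. The series still rests largely on limits: the limit of > 100000 nM in this assay, at which 2 of the 3 values shown sit.

All three groups shown on the sulfonamide nitrogen are phenyl rings carrying halogen, so it remains open how the value in this assay would respond to a phenyl ring carrying an amine or a carboxylic acid. Also open, on these data alone, is whether a change elsewhere on the shared core would move the value further than this position has.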